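Benzyl in Place of Naphthylmethyl on a Weak Cytotoxic Scaffold

A few compounds are considered here, and "the series" means these few. Any claim that something is new, unique, unknown or untested is made for them only; others in the source may bear on it.

Measured so far:
- compound 1 `Cc1cc(S(=O)(=O)/N=C(\N)n2nccc2-c2ccccc2)c(SCc2ccc(Cl)cc2)cc1Cl`: 75000 nM
- compound 2 `Cc1cc(S(=O)(=O)/N=C(\N)n2nccc2-c2ccccc2)c(SCc2cccc3ccccc23)cc1Cl`: 58000 nM

In a functional assay on MCF7 cells (Homo sapiens) for cytotoxicity, read by MTT assay, with a stated time of 72 h (on this read-out higher numbers stand for weaker inhibition and lower numbers for stronger inhibition), compound 1 gives 75000 nM and compound 2 gives 58000 nM. Compound 2 holds the lowest of the two numbers, yet the step of a 1.3-fold lower number from compound 1 to compound 2 (0.11 log units; within the scatter) lies within the scatter, so the two are not separated. Compound 3 `Cc1cc(S(=O)(=O)/N=C(\N)n2nccc2-c2ccccc2)c(SCc2ccccc2)cc1Cl` carries the change (phenyl in place of naphthalen-1-yl on a saturated chain carbon bound to a sulfur). Within the data shown here, the only step that bears on it, a 1.3-fold lower number from compound 1 to compound 2 (0.11 log units; within the scatter), also swapped the group at this place and was small. Compound 3 is therefore expected to show a 1.2-fold higher number from compound 2 to compound 3 (0.08 log units; within the scatter). The number of compound 3 in this assay is estimated at 70000 nM, with a range of 30000 nM to 160000 nM.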

Compound 3, half-maximal inhibitory concentration: 20000 nM
Beside the measured number, compound 3's estimate is 3.5-fold (0.54 log units) above it, and the stated range ends above it.
By their numbers in this assay, from the lowest: compound 3; then compounds 2 and 1 (each within the scatter of the next).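

In this assay this place on the scaffold proves responsive: phenyl in place of naphthalen-1-yl gives a 2.9-fold lower number from compound 2 to compound 3 (0.46 log units; beyond the scatter), and hydrogen in place of chloro on an aromatic carbon gives a 3.8-fold lower number from compound 1 to compound 3 (0.57 log units; beyond the scatter). The two earlier groups could not be separated from each other, but each now stands apart from plain phenyl. Nothing available explains this difference. On these data alone, it remains open how other groups at this place would compare, such as 4-methoxyphenyl, or 2-phenylethyl in place of benzyl.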